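Ester swaps at the cytotoxicity limit

A few compounds are considered here, and "the series" means these few. Any claim that something is new, unique, unknown or untested is made for them only; others in the source may bear on it.

Compound 1 `CC(=O)O[C@H](C/C(C)=C/CO)[C@@]1(C)[C@H](C)CC=C2[C@@H]1CCCC2(C)C` gives > 30000 nM in a functional assay on MCF7 cells (Homo sapiens) for cytotoxicity, read by MTT assay, with a stated time of 72 h (on this read-out higher numbers stand for weaker inhibition and lower numbers for stronger inhibition), which is a limit and not a number. Compound 2 `CCCC(=O)OC/C=C(\C)C[C@@H](O)[C@@]1(C)[C@H](C)CC=C2[C@@H]1CCCC2(C)C` gives > 30000 nM, also a limit. Compound 3 `C/C(=C\CO)C[C@@H](O)[C@@]1(C)[C@H](C)CC=C2[C@@H]1CCCC2(C)C` gives > 30000 nM, also a limit. Compound 1 therefore stands with the others at the limit of > 30000 nM in this assay, at which 3 of the 3 values shown sit, and no rank can be read.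

Compound 4 `COC(=O)/C=C(\C)C[C@@H](OC(C)=O)[C@@]1(C)[C@H](C)CC=C2[C@@H]1CCCC2(C)C` differs from compound 1 by methoxycarbonyl in place of hydroxymethyl on a double-bonded chain carbon bound to a double-bonded chain carbon.

Two measured steps are nearest. Hydrogen in place of acetyl is a step that the two limits leave unreadable from compound 1 to compound 3. Hydrogen in place of propylcarbonyl is a step that the two limits leave unreadable from compound 2 to compound 3. Neither is the change made here and neither offers a size, so no step beyond the scatter and no direction is expected in this assay. The expected step is a number no higher from compound 1 to compound 4 (the limit leaves the size open). For compound 4 the estimated value is 30000 nM, with an expected range of 12000 nM to 60000 nM.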

Compound 4, half-maximal inhibitory concentration: > 30000 nM
Compound 4 ended at the assay's limit; the forecaster's own chance of this, stated with the estimate: 75%; the middle value lies on the limit itself.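

Methoxycarbonyl in place of hydroxymethyl gives no readable step from compound 1 to compound 4, as both values are limits in this assay: the limit of > 30000 nM in this assay, at which 4 of the 4 values shown sit.

The compounds shown leave open how far any of them lies beyond that limit, and which change to the shared core would give a measurable value.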